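A few compounds are considered here, and "the series" means these few. Any claim that something is new, unique, unknown or untested is made for them only; others in the source may bear on it.

Compound 3 `CCC(C)N(c1ccnc(Nc2ccc(C#N)cc2)n1)c1c(F)cc(-c2ccc(C#N)cc2)cc1F` gives 217000 nM in an ADME assay on MT4 cells (Homo sapiens) for cytotoxicity, read by MTT assay, with a stated time of 5 days (a lower number here means that less compound is tolerated, a higher number that more compound is tolerated), the second highest of the three numbers shown, with compound 1 `CCCN(c1ccnc(Nc2ccc(C#N)cc2)n1)c1c(F)cc(-c2ccc(C#N)cc2)cc1F` at 212000 nM nearest and compound 2 `CC(C)CN(c1ccnc(Nc2ccc(C#N)cc2)n1)c1c(F)cc(-c2ccc(C#N)cc2)cc1F` at 241000 nM furthest, both within the scatter. Compound 4 `CCC(C)CN(c1ccnc(Nc2ccc(C#N)cc2)n1)c1c(F)cc(-c2ccc(C#N)cc2)cc1F` differs from compound 3 in one place: 2-methylbutyl in place of sec-butyl on a nitrogen on an aromatic ring. Two earlier steps likewise added a single methyl to the chain on that nitrogen, a 1.1-fold higher number from compound 1 to compound 2 (0.06 log units; within the scatter) and a 1.0-fold higher number from compound 1 to compound 3 (0.01 log units; within the scatter), and the exchange a 1.1-fold lower number from compound 2 to compound 3 (0.05 log units; within the scatter) also stayed within the scatter. Going from sec-butyl to 2-methylbutyl is therefore expected to change the tolerated concentration by no more than the scatter, an estimated step of a 1.0-fold higher number from compound 3 to compound 4 (0.01 log units; within the scatter). Compound 4 is expected to give about 220000 nM in this assay, within a range from 120000 nM to 400000 nM.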

Compound 4, half-maximal cytotoxic concentration: > 255000 nM
Compound 4 was reported as a limit (the forecaster's own chance of this, stated with the estimate: 5%); middle value at least 1.1-fold (0.06 log units) away from the limit.
By their numbers in this assay, from the lowest: compounds 1, 3 and 2 (each within the scatter of the next). At a limit, above all of these: compound 4.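

In this assay compound 4 gives > 255000 nM, which is a limit of the assay and not a number. Its steps are therefore only floors, an at least 1.1-fold higher number from compound 3 to compound 4 (0.07 log units; that floor lies within the scatter), an at least 1.0-fold higher number from compound 2 to compound 4 (0.02 log units; that floor lies within the scatter) and an at least 1.2-fold higher number from compound 1 to compound 4 (0.08 log units; that floor lies within the scatter), so 2-methylbutyl on this nitrogen brings no drop in the tolerated concentration among the compounds shown. Whether the same added group acts alike on two different chains stays unsettled: the same change on two cores in this assay, a 1.0-fold higher number (0.01 log units; within the scatter) from compound 1 to compound 3 and an at least 1.0-fold higher number (0.02 log units; that floor lies within the scatter) from compound 2 to compound 4; the limit leaves it open whether they differ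

The compounds shown leave open whether a longer chain, or a chain carrying an amine, on this nitrogen would move the number beyond the scatter.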